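Dimethylamino in place of acetyl on a shared core

A few compounds are considered here, and "the series" means these few. Any claim that something is new, unique, unknown or untested is made for them only; others in the source may bear on it.

Measured compounds:
compound 1 `COc1cc(C)cc(-c2c(-c3ccnc(-c4ccc(C(C)=O)cc4)c3)cnn2CC#N)c1` — 14%
compound 2 `COc1cc(C)cc(-c2nn(CC#N)cc2-c2ccc(-c3cccc(C(C)=O)c3)nc2)c1` — 14%

In a functional assay on MOLT-4 cells (Homo sapiens) for cytotoxicity, read by sulforhodamine B assay, with a stated time of 48 h, tested at 10 uM (on this read-out lower numbers stand for a stronger effect and higher numbers for a weaker effect at the one concentration tested), compound 1 gives 14%. Compound 2, which carries the same acetyl on a different part of the molecule, gives 14% in this assay; the two values are level at the digits shown and lie within the scatter of each other, so compound 1 stands neither above nor below compound 2 on this read-out.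

Compound 3 `COc1cc(C)cc(-c2c(-c3ccnc(-c4ccc(N(C)C)cc4)c3)cnn2CC#N)c1` has not yet been tested. It differs from compound 1 in one place: dimethylamino in place of acetyl on an aromatic carbon. The change sits on an aromatic carbon of a six-membered aromatic ring of carbon only. For the measured compounds named here, no measured pair shows this exchange, so its size cannot be read from the data. A small step is expected in this assay, likely not far beyond the scatter and, if anything, toward a weaker effect. For compound 3 the expected step is a number 6 percentage points higher from compound 1 to compound 3 (within the scatter). Compound 3 is thus estimated at 20%, with a range from 5% to 45%.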

Compound 3, a percentage reported as activity, at one concentration (the size of the read-out at that concentration, not a potency): 1%
Compound 3: the middle estimate sits 19 percentage points above what was measured, and the stated range ends above it.
By their numbers in this assay, from the lowest: compound 3; then compounds 1 and 2 (each within the scatter of the next).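

In this assay the exchange of acetyl for dimethylamino reads as a number 13 percentage points lower from compound 1 to compound 3 (beyond the scatter) and, on this read-out, that means a stronger effect. The earlier compounds shown here both carried acetyl, so they could not show that the read-out responds to the group held at this position. Here the leaving and entering groups match in heavy-atom count and in hydrogen-bond acceptors, yet the change still registers beyond the scatter, and nothing at hand accounts for the shift.

On these data alone, whether a plain amino group, a methylamino group or a ring amine such as morpholine at this position would do the same remains open. Also open, as far as these compounds go, is whether dimethylamino in place of the acetyl of compound 2 would give a similar step.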